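A few compounds are considered here, and "the series" means these few. Any claim that something is new, unique, unknown or untested is made for them only; others in the source may bear on it.

Values in a functional assay on A549 cells (Homo sapiens) for antiproliferative activity, read by MTT assay, with a stated time of 72 h (a lower number here means a stronger inhibitor, a higher number a weaker inhibitor), for the series so far

compound 1 `Cc1cc(C)cc(OCCCON2C(N)=NC(N)=NC23CCOCC3)c1` gives 710 nM
compound 2 `NC1=NC2(CCOCC2)N(OCCCOc2cccc(Br)c2)C(N)=N1` gives 160 nM
compound 3 `NC1=NC2(CCOCC2)N(OCCCOc2ccc(Br)cc2)C(N)=N1` is not yet measured

Compound 2 holds the lower of the two numbers, and the gap to compound 1 lies beyond the scatter. Compound 3 carries 4-bromophenyl in place of 3-bromophenyl on an oxygen on a saturated carbon. Going by the values given here, only one measured step bears on this change, a modest one at the same place (a 4.4-fold lower number from compound 1 to compound 2 (0.65 log units; beyond the scatter)). That step exchanged one group for another and did not move a bromine, so it gives only a rough guide to size and none to direction. A shift of similar or smaller size is expected, with a slight lean towards a higher number and probably nothing beyond the scatter (a 1.4-fold higher number from compound 2 to compound 3 (0.14 log units; within the scatter)). For compound 3 the expected value is 220 nM within an estimated range of 70 nM to 650 nM in this assay at this stage.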

Compound 3, half-maximal inhibitory concentration: 280 nM
For compound 3 the middle estimate is 1.3-fold (0.10 log units) below the measured one; the range from low to high includes it.
By their numbers in this assay, from the lowest: compounds 2 and 3 (each within the scatter of the next); then compound 1.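

In this assay, going by these compounds alone, moving the bromine gives the first comparison at this position with the same atoms joined differently (a 1.8-fold higher number from compound 2 to compound 3 (0.24 log units; within the scatter)), so 3-bromophenyl and 4-bromophenyl cannot be told apart in this assay. The step from 3,5-dimethylphenyl to 4-bromophenyl (a 2.5-fold lower number from compound 1 to compound 3 (0.40 log units; beyond the scatter)) lies beyond the scatter, as does the step to 3-bromophenyl, so the two bromophenyl compounds both stand apart from compound 1. No supporting measurement accounts for either step.

The compounds shown do not separate the effect of bromine from that of having one ring substituent rather than two, a question that a 3-methylphenyl group would address. From the compounds shown here alone, it also remains open whether the tolerance for moving the bromine would hold with a chlorine in its place or with a longer chain.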